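Changing the Amide Substituent of Compound 1

The compounds below may be only part of what the source reports. "The series", "measured", "known", "first", "only" and "open" are said of these compounds alone.

Compound 1 `Cc1cccc(N(C)c2cc(Nc3cccc(C(=O)N(CC(C)C)CC(C)C)c3)ncn2)c1` was tested in an assay on isolated protein for inhibition of calcium/calmodulin-dependent protein kinase type IV (Homo sapiens), read by HTRF, tested at 10 uM (on this read-out higher numbers stand for more inhibition at the one concentration tested (going by the name of the read-out) and lower numbers for less inhibition), where compound 1 gives 0%. Compound 2 `O=C(CN1CCN(c2ncnc3c2CN(Cc2ccccc2)CC3)CC1)Nc1cc(F)ccc1F` gives 0% in this assay, and compound 3 `O=C(C1CCN(c2nccc(Nc3ccccc3)n2)CC1)N1CC[C@@H](O)C1` gives 0%. Compound 1 is thus level with compounds 2 and 3 at the digits reported, all three showing no inhibition at the single concentration, with the differences among them within the usual scatter. Compound 4 `Cc1cccc(N(C)c2cc(Nc3cccc(C(=O)N4CCCC5CCCCC54)c3)ncn2)c1` has not yet been measured in this assay. It differs from compound 1 by a group of 10 heavy atoms (9 carbon, 1 nitrogen; one six-membered non-aromatic ring of carbon only, one six-membered non-aromatic ring with 1 hetero atom) in place of a group of 9 heavy atoms (8 carbon, 1 nitrogen; no ring), on a carbonyl carbon. With every measured compound at the same reading, nothing in the data suggests this change should move the result beyond the scatter in either direction. The expected step is a number 2 percentage points higher from compound 1 to compound 4 (within the scatter), meaning none beyond the scatter. Compound 4 is estimated to give 2% in this assay, within a range from -8% to 14%.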

Compound 4, a percentage reported as inhibition, at one concentration (the size of the read-out at that concentration, not a potency): 0%
The estimate for compound 4 lay 2 percentage points above the measured number; the range from low to high includes it.
By their numbers in this assay, from the lowest: compounds 1, 2, 3 and 4 (each within the scatter of the next).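

Replacing the diisobutylamino group on the carbonyl carbon with the group carrying two six-membered non-aromatic rings gives, in this assay, no change at the digits printed from compound 1 to compound 4 (within the scatter). For the compounds shown here, this is the first step read at this position, and it shows that this ring-bearing group brings no inhibition into view where the ringless group showed none. No supporting data bear on why the reading stays the same. Going by these compounds, what remains open is whether a smaller group on this carbonyl carbon, such as dimethylamino, or a piperidine bearing a carboxylic acid, would give any measurable inhibition.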